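Acetyl in place of hydroxy(phenyl)methyl on the shared core

The compounds below may be only part of what the source reports. "The series", "measured", "known", "first", "only" and "open" are said of these compounds alone.

Measured so far in a functional assay on L5178Y cells (Mus musculus); a higher number here means a more potent compound, by a factor of ten per unit of this negative logarithm, a lower number a less potent compound:
compound 1 `CC1(C)N=C(N)N=C(N)N1c1cccc(C(O)c2ccccc2)c1`: 4.17
compound 2 `CCCCCCCCCOc1cccc(N2C(N)=NC(N)=NC2(C)C)c1`: 6.57
compound 3 `CCCCCCCCCCCCCCOc1cccc(N2C(N)=NC(N)=NC2(C)C)c1`: 6.49

Compound 1 stands lowest of the three numbers in this assay. Compound 3 is nearest to it, and compound 2 furthest; both gaps from compound 1 are beyond the scatter. Between compound 2 and compound 3 the one step measured so far, a number 0.08 log units lower from compound 2 to compound 3 (within the scatter), is pentyl in place of hydrogen on a saturated chain carbon, nine bonds along the chain from an oxygen on an aromatic ring.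

Compound 4 `CC(=O)c1cccc(N2C(N)=NC(N)=NC2(C)C)c1` is not yet measured. It differs from compound 1 by acetyl in place of hydroxy(phenyl)methyl on an aromatic carbon, sitting on an aromatic carbon of a six-membered aromatic ring of carbon only, meta to a large group.

For the measured compounds named here, no measured step bears on this change: the step from compound 2 to compound 3 alters a chain far from the core and lies within the scatter, and nothing measured so far exchanges one group on this aromatic carbon for another of a different kind. The estimate therefore rests on compound 1 alone, with a wide range. For compound 4 the expected value in this assay is 4.4, between 3.4 and 5.4. This means an expected step of a number 0.23 log units higher from compound 1 to compound 4 (within the scatter).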

Compound 4, logarithm of the reciprocal of the active concentration, log(1/C): 4.56
Estimate against measurement, compound 4: 0.16 log units below, within the range that was stated.
By their numbers in this assay, from the lowest: compound 1; then compound 4; then compounds 3 and 2 (each within the scatter of the next).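

In this assay, for the compounds shown here, the only step that exchanges one kind of group for another on this aromatic carbon, meta to a large group, is a number 0.39 log units higher from compound 1 to compound 4 (beyond the scatter) and gives a first reading of how the position responds to a change of group. The exchange replaces hydroxy(phenyl)methyl, with 8 heavy atoms, a six-membered aromatic ring and a hydrogen-bond donor, by acetyl, with 3 heavy atoms, no ring and no donor, and the number does not fall, so in this pair the ring and the donor are not needed to hold the value of compound 1. These changes arrive together in a single pair, and no measurement shown separates them or explains the step.

Still open, going by these compounds, is how benzoyl, which keeps a ring alongside a carbonyl, and 1-hydroxyethyl, which keeps the hydroxyl without the ring, would stand on this aromatic carbon. Also open is where short ethers such as methoxy or butoxy would fall on the same carbon, since the only ether chains shown are the two on compound 2 and compound 3.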